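This account rests on a few compounds, and the source may have more. Where it says the series, first, only, none or still open, it means among the compounds named here.

Compound 1 `O=C(Nc1cccc(-n2cc(-c3ccncc3)c(-c3ccc(Cl)c(O)c3)n2)c1)Nc1ccc(Cl)c(Cl)c1`: 9490 nM
Compound 2 `COc1cc(-c2nn(-c3cccc(NC(=O)Nc4cccc(C(F)(F)F)c4)c3)cc2-c2ccncc2)ccc1Cl`: 1750 nM
Compound 3 `COc1cc(-c2nn(-c3cccc(NC(=O)Nc4ccc(Cl)c(C(F)(F)F)c4)c3)cc2-c2ccncc2)ccc1Cl`: 1540 nM

All three were measured in a functional assay on COLO 205 cells (Homo sapiens) for inhibition, read by sulforhodamine B assay, with a stated time of 48 h; a lower number here means a stronger inhibitor of growth, a higher number a weaker inhibitor of growth. Compound 3 has the lowest number of the three; compound 2 stands nearest, and the step of a 1.1-fold lower number from compound 2 to compound 3 (0.06 log units; within the scatter) is within the scatter, so these two cannot be ranked. Compound 1 gives a higher number than compound 3, and that gap lies beyond the scatter. Compound 4 `COc1cc(-c2nn(-c3cccc(NC(=O)Nc4ccc(Cl)c(Cl)c4)c3)cc2-c2ccncc2)ccc1Cl` differs from compound 3 by chloro in place of trifluoromethyl on an aromatic carbon. For the measured compounds named here, no measured step covers this exchange; the single recorded step, a 1.1-fold lower number from compound 2 to compound 3 (0.06 log units; within the scatter), concerns another change and was flat. Compound 1 carries the same 3,4-dichlorophenyl as compound 4 but also differs elsewhere, so its higher number is only a hint. A modest rise is expected for compound 4, a 1.6-fold higher number from compound 3 to compound 4 (0.21 log units; within the scatter), giving an estimated 2500 nM within 1000 nM to 7000 nM.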

Compound 4, concentration for total growth inhibition: 1720 nM
Beside the measured number, compound 4's estimate is 1.5-fold (0.16 log units) above it, within the range that was stated.
By their numbers in this assay, from the lowest: compounds 3, 4 and 2 (each within the scatter of the next); then compound 1.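

In this assay, chloro in place of trifluoromethyl at this position makes no readable difference (a 1.1-fold higher number from compound 3 to compound 4 (0.05 log units; within the scatter)), and 3,4-dichlorophenyl in place of 3-(trifluoromethyl)phenyl likewise gives no readable difference (a 1.0-fold lower number from compound 2 to compound 4 (0.01 log units; within the scatter)). For the compounds shown here, the one clear gap comes with methyl in place of hydrogen on the oxygen (a 5.5-fold lower number from compound 1 to compound 4 (0.74 log units; beyond the scatter)), which compound 4 isolates as a single change for the first time. No measurement shown accounts for these results. From the compounds shown here alone, whether an amine or a carboxylic acid at the chloro position would stay in this range remains open, as does the effect of a longer chain on that oxygen.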